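Replacing cyano with 4-chlorophenyl at a measured limit

The source may hold more compounds than are shown below. What is called first, only, known or untested is meant among the compounds shown, and "the series" means these compounds.

Within the data shown here, only two compounds have been tested so far, and neither has given a number. In a functional assay on Jurkat cells (Homo sapiens) for cytotoxicity, with a stated time of 72 h (a higher number here means that more compound is needed for the effect, a lower number that less compound is needed), compound 1 (`C=C[C@@](C)(/C=C/c1ccc(O)cc1)CCCO`) gives > 49000 nM and this is a limit, not a measured value. In this assay compound 2 (`C=C[C@@](C)(/C=C/c1ccc(O)c(/C=C/C#N)c1)CCC=C(C)C`) gives > 49000 nM and this too is a limit, not a measured value. Compound 2 therefore has only a boundary to its name, the same one that compound 1 reached.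

Compound 3 (`C=C[C@@](C)(/C=C/c1ccc(O)c(/C=C/c2ccc(Cl)cc2)c1)CCC=C(C)C`) differs from compound 2 in one place. The change is 4-chlorophenyl in place of cyano on a double-bonded chain carbon bound to a double-bonded chain carbon and it puts 4-chlorophenyl in place of cyano on a double-bonded chain carbon bound to a double-bonded chain carbon. Among the measured compounds shown here, no measured step exists to show what such a change does. The expectation rests on the size of the entering group alone and is only tentative. In this assay the expected outcome is a modest move towards less compound being needed, with the estimated at least 2.4-fold lower number from compound 2 to compound 3 (0.38 log units; beyond the scatter) as its size, and compound 3 may yet stop at the same limit. For compound 3 the estimate is 20000 nM with an expected range from 7000 nM to 49000 nM in this test.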

Compound 3, half-maximal effective concentration: > 49000 nM
Compound 3 was reported as a limit; the forecaster's own chance of this, stated with the estimate: 40%; at least 2.4-fold (0.38 log units) between middle value and limit.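

Compound 3, like compound 2, is reported only as a limit in this assay, so no step between them can be read: the limit of > 49000 nM in this assay, at which 3 of the 3 values shown sit.

The compounds shown leave open what number, if any, each would reach in this assay, and so what 4-chlorophenyl in place of cyano does to that number.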